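A few compounds are considered here, and "the series" means these few. Any claim that something is new, unique, unknown or untested is made for them only; others in the source may bear on it.

Among the compounds with values here, in an ADME assay on microsomes from liver (Rattus norvegicus) for metabolic stability (a higher number here means faster removal of the compound, a lower number slower removal), three compounds have numbers so far. Compound 1 `CNc1nc(NC)nc(NC2(C#N)CCCCC2)n1` gives 210 mL/min/kg and compound 2 `CNc1nc(NC2(C#N)CCCCCC2)nc(-n2cncn2)n1` gives 276 mL/min/kg so these two lie within the scatter of each other. Compound 3 `CCCC(C#N)(CC)Nc1nc(NC)nc(-n2cncn2)n1` gives 29 mL/min/kg and so lies beyond the scatter below compound 1. No two of these compounds differ in one place only, which leaves no measured step to guide the next one.

Compound 4 `CNc1nc(NC2(C#N)CCCCC2)nc(SC)n1` departs from compound 1 at a single place, with methylsulfanyl in place of methylamino on an aromatic carbon. Within the data shown here, with no measured example of this change, the expectation in this assay is for no step beyond the scatter, and compound 1 at 210 mL/min/kg is the reference for that expectation. The expected change, a 1.2-fold higher number from compound 1 to compound 4 (0.08 log units; within the scatter) and thus a slight rise at most, stays within the scatter. Compound 4 is estimated to give 250 mL/min/kg with an expected range from 110 mL/min/kg to 500 mL/min/kg in this measurement.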

Compound 4, clearance: 579 mL/min/kg
Compound 4: the middle estimate sits 2.3-fold (0.36 log units) below what was measured; measured number above the stated range.
By their numbers in this assay, from the lowest: compound 3; then compounds 1 and 2 (each within the scatter of the next); then compound 4.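

Within the data shown here, the first single-place step in this assay comes from putting methylsulfanyl in place of methylamino, a 2.8-fold higher number from compound 1 to compound 4 (0.44 log units; beyond the scatter), so this aromatic carbon between two ring nitrogen atoms is not indifferent to what it carries. The two groups have the same count of heavy atoms, yet the change, which also takes the count of hydrogen-bond donors from one to none, moves the number beyond the scatter, and in the upward direction. Nothing measured here accounts for the rise, so its cause remains unassigned.

The compounds shown leave open whether the rise follows the sulfur or the lost hydrogen-bond donor, a question that a methoxy or ethyl group at this place would bear on. From the compounds shown here alone, whether the step keeps its size with other groups elsewhere on the core also stays open.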